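Ethoxycarbonyl in place of methyl: compound 3 to compound 4

The compounds below may be only part of what the source reports. "The series", "measured", "known", "first", "only" and "open" are said of these compounds alone.

- compound 1 `CC(C)(C)NC(=O)CCc1cccc2c1B(O)OC2` gives > 100000 nM (a limit)
- compound 2 `O=C(CCc1cccc2c1B(O)OC2)NC1CCCCC1` gives > 100000 nM (a limit)
- compound 3 `Cc1ccc(NC(=O)CCc2cccc3c2B(O)OC3)cc1` gives 4500 nM
- compound 4 `CCOC(=O)c1ccc(NC(=O)CCc2cccc3c2B(O)OC3)cc1` is not yet measured

Going by the values given here, compound 3 holds the only number in a functional assay on HCT-116 cells (Homo sapiens) for antiproliferative activity, read by MTT assay, with a stated time of 72 h (a higher number here means a weaker inhibitor, a lower number a stronger inhibitor), with 4500 nM as its value. The other two values are limits (the limit of > 100000 nM in this assay, at which 2 of the 3 values shown sit).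

Compound 4 carries ethoxycarbonyl in place of methyl on an aromatic carbon, para to a large group (ethoxycarbonyl in place of methyl on an aromatic carbon). The nearest measured changes are on the amide-type nitrogen, and both are large: an at least 22-fold lower number from compound 1 to compound 3 (1.34 log units; beyond the scatter) and an at least 22-fold lower number from compound 2 to compound 3 (1.34 log units; beyond the scatter). Neither alters the methyl position, so neither sizes this change directly, and no step beyond the scatter is expected in this assay. The expected step is a 1.3-fold higher number from compound 3 to compound 4 (0.12 log units; within the scatter) here. Compound 4 is estimated at 6000 nM, within an expected range of 1500 nM to 30000 nM here.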

Compound 4, half-maximal inhibitory concentration: > 100000 nM
Compound 4 gave a limit, no number; the forecaster's own chance of this, stated with the estimate: 12%; at least 16-fold (1.22 log units) between middle value and limit.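

On the aromatic carbon para to a large group, the first measured change is large: in this assay, ethoxycarbonyl in place of methyl gives an at least 22-fold higher number from compound 3 to compound 4 (1.34 log units; beyond the scatter). The earlier steps shown here changed only the amide-type nitrogen, so this shows that a change at this position alone, with that nitrogen's aryl group kept, can remove the readable value. Compound 4 gives a limit and no number, placing it with the other compounds at that limit: the limit of > 100000 nM in this assay, at which 3 of the 4 values shown sit.

The full size of the step stays unread. On these data alone, whether an amine or a carboxylic acid in place of methyl would keep a readable number remains open.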